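The compounds below may be only part of what the source reports. "The series", "measured", "known", "first", "only" and "open" are said of these compounds alone.

Measured in a physicochemical assay for solubility, measured as kinetic solubility; a higher number here means a more soluble compound, a lower number a less soluble compound:
- Compound 1 `O=C(Nc1ccnnc1)c1cc(C(F)(F)F)ccc1OCc1ccccc1`: < 1000 nM (a limit)
- Compound 2 `O=C(Nc1ccnnc1)c1cc(N2CCCC2)ccc1OCc1ccccc1`: 35000 nM
- Compound 3 `O=C(Nc1ccnnc1)c1cc(N2CCNCC2)ccc1OCc1ccccc1`: 98000 nM

Compound 3 gives 98000 nM, the higher of the two actual numbers. The gap between those two is modest: a 2.8-fold higher number from compound 2 to compound 3 (0.45 log units; beyond the scatter). The entry for compound 1 is a limit, not a number.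

Compound 4 `N#CC1CCN(c2ccc(OCc3ccccc3)c(C(=O)Nc3ccnnc3)c2)CC1` carries 4-cyanopiperidin-1-yl in place of piperazin-1-yl on an aromatic carbon.

The large steps, an at least 35-fold higher number from compound 1 to compound 2 (1.54 log units; beyond the scatter) and an at least 98-fold higher number from compound 1 to compound 3 (1.99 log units; beyond the scatter), both replace trifluoromethyl and start from a limit, so they offer little guidance here. Compound 2, at 35000 nM, also lacks piperazin-1-yl and is the closest guide, so a modest fall is expected in this assay. The expected change is a 4.9-fold lower number from compound 3 to compound 4 (0.69 log units; beyond the scatter). For compound 4 the estimate is 20000 nM, with an expected range of 4000 nM to 60000 nM.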

Compound 4, solubility: < 1000 nM
Compound 4 gave a limit, no number (the forecaster's own chance of this, stated with the estimate: 10%); middle value at least 20-fold (1.30 log units) from the limit.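

Attaching a saturated nitrogen ring at this position does not by itself secure a high number in this assay: 4-cyanopiperidin-1-yl gives an at least 98-fold lower number from compound 3 to compound 4 (1.99 log units; beyond the scatter), and an at least 35-fold lower number from compound 2 to compound 4 (1.54 log units; beyond the scatter). Compound 4 therefore falls with compound 1 rather than with the other two ring compounds, and the step between compound 1 and compound 4 cannot be read, as both entries are limits: the limit of < 1000 nM in this assay, at which 2 of the 4 values shown sit.

The compounds shown do not separate the contribution of the nitrile from that of the piperidine ring. A plain piperidin-1-yl group would address that question, and a piperidine carrying a carboxylic acid in place of the nitrile would extend it.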